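Removing the fluorophenyl ring from compound 1

The compounds below may be only part of what the source reports. "The series", "measured", "known", "first", "only" and "open" are said of these compounds alone.

Compound 1, with the structure `O=C1CC(c2ccccc2OCc2cccc(F)c2)Oc2ccccc21`, has the higher number of the two measured compounds. In a functional assay on J774.A1 cells (Mus musculus) for inhibition, read by immunoassay, with a stated time of 12 h, tested at 30 uM (a higher number here means more inhibition at the concentration tested (going by the name of the read-out), a lower number less inhibition), compound 1 gives 92.7%, the higher of two numbers. For the measured compounds named here, its nearest neighbour, compound 2, `O=C1CC(c2ccccc2OCc2ccc(F)cc2)Oc2ccccc21`, gives 42.1% in this assay, and the only measured step, a number 50.6 percentage points lower from compound 1 to compound 2 (beyond the scatter), is large and lies beyond the scatter.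

Compound 3, `COc1ccccc1C1CC(=O)c2ccccc2O1`, has not yet been measured. It differs from compound 1 in one place: hydrogen in place of 3-fluorophenyl on a saturated chain carbon bound to an oxygen on an aromatic ring. Cut one bond further out, the 3-fluorobenzyl becomes a methyl.

Going by the values given here, no measured step removes the whole 3-fluorophenyl, so the expectation rests on indirect ground. The step from compound 1 to compound 2 shows that merely shifting the fluorine within that ring cost a large amount of inhibition, which suggests the ring itself matters to the read-out. Losing it entirely is therefore expected to lower the number at least as much. Compound 3 is estimated at 25%, within 0% to 55%, a step of a number 67.7 percentage points lower from compound 1 to compound 3 (beyond the scatter).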

Compound 3, a percentage reported as inhibition, at one concentration (the size of the read-out at that concentration, not a potency): 38.3%
Compound 3: the middle estimate sits 13.3 percentage points below what was measured; the range from low to high includes it.
By their numbers in this assay, from the lowest: compounds 3 and 2 (each within the scatter of the next); then compound 1.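

Taking the 3-fluorophenyl away altogether in this assay gives a number 54.4 percentage points lower from compound 1 to compound 3 (beyond the scatter) and so shows for the first time that the high number of compound 1 is tied to the group at this place, not to the shared core alone. The 4-fluorophenyl, in contrast, cannot be told apart from hydrogen on the saturated chain carbon bound to an oxygen on an aromatic ring, with a number 3.8 percentage points lower from compound 2 to compound 3 (within the scatter), so the presence of a fluorophenyl ring there is not enough by itself, and the earlier large step between the two fluorine placements now reads as the loss of all that the 3-fluorophenyl adds. Nothing in hand explains why the two fluorophenyl groups part in this way.

Going by these compounds, it remains open whether the fluorine itself is needed, which a plain phenyl at this place would address, and whether another atom can stand in for it, as in a 3-chlorophenyl. Also open, on these data alone, is whether the ring can give way to a different group on the same carbon, such as a cyclohexyl or a short chain ending in an amine.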